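The compounds below may be only part of what the source reports. "The series", "measured", "known", "first", "only" and "open" are said of these compounds alone.

Measured in a functional assay on A549 cells (Homo sapiens) for antiproliferative activity, read by MTT assay, with a stated time of 48 h; on this read-out lower numbers stand for stronger inhibition and higher numbers for weaker inhibition:
- compound 1 `N#Cc1ncn(-c2ccc(F)cc2)c1/N=C/c1ccc([N+](=O)[O-])cc1`: 18100 nM
- compound 2 `COc1cc(/C=N/c2c(C#N)ncn2-c2ccc(F)cc2)ccc1O`: 13600 nM
- compound 3 `COc1ccc(/C=N/c2c(C#N)ncn2-c2ccc(F)cc2)cc1`: 17100 nM

Compound 3, at 17100 nM, lies within the scatter of both compound 1 and compound 2, so the three form one flat group. Compound 4 `COc1ccc(/C=N/c2c(C#N)ncn2-c2ccc(F)cc2)cc1OC` differs from compound 3 by methoxy in place of hydrogen on an aromatic carbon, ortho to a methoxy group and meta to a large group. Going by the values given here, no measured step makes this exact change. The nearest evidence is a 1.1-fold lower number from compound 1 to compound 3 (0.02 log units; within the scatter), a swap of nitro for methoxy that stayed small. Compound 2, with a methoxy and a hydroxy on that ring, gives 13600 nM, which also stays in the group. In this assay, no step beyond the scatter is therefore expected, and the estimate is a 1.1-fold lower number from compound 3 to compound 4 (0.06 log units; within the scatter). The expected value for compound 4 is 15000 nM, with an estimated range of 8000 nM to 28000 nM.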

Compound 4, half-maximal inhibitory concentration: 2960 nM
Compound 4: middle estimate off by 5.1-fold (0.70 log units), on the high side; measured number below the stated range.
By their numbers in this assay, from the lowest: compound 4; then compounds 2, 3 and 1 (each within the scatter of the next).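

In this assay, methoxy on the aromatic carbon ortho to a methoxy group and meta to a large group gives a 5.8-fold lower number from compound 3 to compound 4 (0.76 log units; beyond the scatter), so this ring position can move the number beyond the scatter, which the flat group of earlier compounds had not shown. Methyl on the hydroxy oxygen of compound 2 gives a 4.6-fold lower number from compound 2 to compound 4 (0.66 log units; beyond the scatter), so the ring of compound 2, with its free hydroxy, does not match the two methoxy groups of compound 4. Nothing available explains the gain. On these data alone, whether ethoxy or an amine at this position would give a similar step remains open. So does whether a single methoxy at this position, without the other one, would suffice.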